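The source may hold more compounds than are shown below. What is called first, only, known or untested is meant among the compounds shown, and "the series" means these compounds.

Compound 3 `O=C(COc1ccc2cc(/C=C3/SC(=O)NC3=O)ccc2c1)Nc1cccc(C(F)(F)F)c1` gives only a limit in an assay on isolated protein for inhibition of histone deacetylase 8 (Homo sapiens), with a stated time of 1 h (on this read-out higher numbers stand for weaker inhibition and lower numbers for stronger inhibition), namely > 50000 nM. Compound 1 `O=C(COc1ccc2cc(/C=C3/SC(=O)NC3=O)ccc2c1)Nc1cc(Cl)cc(C(F)(F)F)c1` likewise reaches only a limit, > 50000 nM. Going by the values given here, compound 2 `COc1cccc(NC(=O)COc2ccc3cc(/C=C4/SC(=O)NC4=O)ccc3c2)c1` gives 7600 nM in this assay, the sole numerical value of the three. Within the series, an at least 6.5-fold lower number from compound 1 to compound 2 (0.81 log units; beyond the scatter) and an at least 6.5-fold higher number from compound 2 to compound 3 (0.81 log units; beyond the scatter), while a step that the two limits leave unreadable from compound 1 to compound 3. Note (the limit of > 50000 nM in this assay, at which 2 of the 3 values shown sit). The next compound, compound 4 `O=C(COc1ccc2cc(/C=C3/SC(=O)NC3=O)ccc2c1)Nc1cccc(F)n1`, differs from compound 3 by 6-fluoropyridin-2-yl in place of 3-(trifluoromethyl)phenyl on an amide-type nitrogen. Among the compounds with values here, no measured step alters this part of the molecule in the same way; the readable steps concern only methoxy against trifluoromethyl. Compound 4 is expected to remain weak in this assay, with an estimated value of 40000 nM (range 8000 nM to 200000 nM). The expected step is then an at least 1.2-fold lower number from compound 3 to compound 4 (0.09 log units; that floor lies within the scatter), likely again ending at a limit.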

Compound 4, half-maximal inhibitory concentration: 7200 nM
For compound 4 the middle estimate is 5.6-fold (0.74 log units) above the measured one; measured number below the stated range.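

With 6-fluoropyridin-2-yl on the amide-type nitrogen, the only ring here with a hetero atom, inhibition becomes readable again, with an at least 6.9-fold lower number from compound 3 to compound 4 (0.84 log units; beyond the scatter) and an at least 6.9-fold lower number from compound 1 to compound 4 (0.84 log units; beyond the scatter). This ring and 3-methoxyphenyl cannot be told apart, with a 1.1-fold lower number from compound 2 to compound 4 (0.02 log units; within the scatter), so a methoxy group is not the only route to a numerical value at this position. The two larger steps are floors only: the limit of > 50000 nM in this assay, at which 2 of the 4 values shown sit. Going by these compounds, it remains open whether the ring nitrogen or the fluorine accounts for the difference from 3-(trifluoromethyl)phenyl; unsubstituted pyridin-2-yl and 6-methoxypyridin-2-yl would separate these.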